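Longer side chain on the amide nitrogen of compound 3

This account rests on a few compounds, and the source may have more. Where it says the series, first, only, none or still open, it means among the compounds named here.

Measured compounds in a functional assay on the whole organism for inhibition, with Rattus norvegicus as the target, at a dose of 10 mg/kg by the oral route; a higher number here means more inhibition at the dose given (going by the name of the read-out), a lower number less inhibition:
- compound 1, `COc1cccc([C@H]2O[C@H](CC(=O)NCCCCC(=O)O)C(=O)N(CC(C)(C)CO)c3ccc(Cl)cc32)c1OC`: 50%
- compound 2, `COc1cccc([C@H]2O[C@H](CC(=O)N3CCC(CC(=O)O)CC3)C(=O)N(CC(C)(C)CO)c3ccc(Cl)cc32)c1OC`: 77%; 64% (2 entries)
- compound 3, `COc1cccc([C@H]2O[C@H](CC(=O)N[C@H](C)C(=O)O)C(=O)N(CC(C)(C)CO)c3ccc(Cl)cc32)c1OC`: 31%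

Compound 3 gives 31% in this assay, the lowest of the two single numbers, with compound 1 giving 50% and compound 2, measured twice, giving 77%; 64% (2 entries) (the several entries of compound 2 in this assay, 77%; 64% (2 entries)). Within the data shown here, the one step that reaches compound 3 is a number 19 percentage points lower from compound 1 to compound 3 (beyond the scatter), a modest drop beyond the scatter.

Compound 4, `COc1cccc([C@H]2O[C@H](CC(=O)NC(CC(C)C)C(=O)O)C(=O)N(CC(C)(C)CO)c3ccc(Cl)cc32)c1OC`, differs from compound 3 in this way: 1-carboxy-3-methylbutyl in place of 1-carboxyethyl on an amide-type nitrogen. Among the measured compounds shown here, no measured step changes the carboxylic acid's side chain in just this way; the step from compound 1 to compound 3 moved the acid and shortened the chain at once, so it only loosely bears on this change. With the acid kept in place and three further carbon atoms added, no step beyond the scatter is expected; a small rise in inhibition at this dose is the estimate, a number 9 percentage points higher from compound 3 to compound 4 (within the scatter), with the uncertainty being wide. Compound 4 is therefore expected to give about 40% in this assay, between 20% and 62%.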

Compound 4, a percentage reported as inhibition, in the whole organism at one dose (the size of the read-out at that dose, not a potency): 14%
Beside the measured number, compound 4's estimate is 26 percentage points above it, and the stated range ends above it.
By their numbers in this assay, from the lowest: compound 4; then compound 3; then compound 1.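

Adding carbon atoms to the group on the amide nitrogen, with the carboxylic acid kept on the same carbon, does not raise the number in this assay: a number 17 percentage points lower from compound 3 to compound 4 (beyond the scatter). The branched 1-carboxy-3-methylbutyl group also falls well short of the 4-carboxybutyl group, with a number 36 percentage points lower from compound 1 to compound 4 (beyond the scatter). Among compound 1, compound 3 and compound 4, the two 1-carboxy groups give the lower numbers, a pattern resting on these compounds alone, and no measurement at hand accounts for it.

On these data alone, it remains open whether the fall follows the added carbon atoms or their branching, which a straight 1-carboxypentyl group or a 1-carboxy-2-phenylethyl group could help to separate. As far as these compounds go, the group in compound 4 also has no defined stereocentre, unlike the 1-carboxyethyl group in compound 3, so the role of spatial arrangement at that carbon is unknown.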